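The source may hold more compounds than are shown below. What is called first, only, known or untested is meant among the compounds shown, and "the series" means these compounds.

Working notes on the series in an assay on isolated protein for inhibition of Rho-associated protein kinase 1 (Homo sapiens), read by scintillation counting, radiometric assay and 33P incorporation, with a stated time of 40 min, in the presence of a further agent that is not named here; a higher number here means a weaker inhibitor, a lower number a stronger inhibitor. Two compounds carry numbers. Compound 1 `O=C(COc1ccc2c(=O)ccoc2c1)Nc1cccc(NC(=O)c2ccc(F)cc2)c1` gives 129 nM, the lowest of the two values shown. Compound 2 `CN(C)c1ccc(S(=O)(=O)Nc2cccc(NC(=O)COc3ccc4c(=O)ccoc4c3)c2)cc1` gives 803 nM, a higher number lying beyond the usual scatter of this assay. Among the measured compounds shown here, no pair of measured compounds differs in a single place, so no measured single-point step stands behind the next move.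

Compound 3 `Nc1cccc(C(=O)Nc2cccc(NC(=O)COc3ccc4c(=O)ccoc4c3)c2)c1` has not been measured. It differs from compound 1 as follows: 3-aminophenyl in place of 4-fluorophenyl on a carbonyl carbon. For the measured compounds named here, with no measured step of this kind to lean on, the size of the change from compound 1 to compound 3 is open; a modest shift in either direction, or none beyond the scatter, is the working assumption, with the expected step of a 1.6-fold higher number from compound 1 to compound 3 (0.19 log units; within the scatter). For compound 3 the expected value in this assay is 200 nM, within a range of 60 nM to 700 nM.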

Compound 3, half-maximal inhibitory concentration: 670 nM
Beside the measured number, compound 3's estimate is 3.4-fold (0.53 log units) below it, and the stated range covers the measured number.
By their numbers in this assay, from the lowest: compound 1; then compounds 3 and 2 (each within the scatter of the next).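

Among the compounds shown here, compound 3 gives the first measured single-point step: 3-aminophenyl in place of 4-fluorophenyl on a carbonyl carbon gives a 5.2-fold higher number from compound 1 to compound 3 (0.72 log units; beyond the scatter) in this assay, so the number at this position responds to the group carried there. The exchange keeps one six-membered aromatic ring of carbon only but swaps fluorine for an amine, adds a hydrogen-bond donor and a hydrogen-bond acceptor, and also moves the substituent from the 4-position name to the 3-position name, so this single step bundles these differences together. No measurement on hand bears on why the number rises.

Still open, from the compounds shown here alone, is whether the step follows the amine itself or its place on the ring, which 4-aminophenyl and 3-fluorophenyl on the same carbonyl would separate. Also open, going by these compounds, is how an unsubstituted phenyl, a methoxy group or a carboxylic acid would read at this position.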